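The source may report more compounds than this note shows. Statements on the series, on what has been measured and on what is new or still open speak of the compounds shown alone.

Among the compounds with values here, in a functional assay on HepG2 cells (Homo sapiens) for antiproliferative activity, read by MTT assay, with a stated time of 48 h (a lower number here means a stronger inhibitor, a higher number a weaker inhibitor), compound 1 `O=C(Nc1cccc(C(F)(F)F)c1)Nc1nnc(Sc2ncnc3scc(-c4ccncc4)c23)s1` gives 15300 nM, the lowest of the two numbers known, while compound 2 `Cc1ccc(NC(=O)Nc2nnc(Sc3ncnc4scc(-c5ccncc5)c34)s2)cc1` gives 52000 nM. Within the data shown here, the single measured step, a 3.4-fold higher number from compound 1 to compound 2 (0.53 log units; beyond the scatter), exchanged the aryl group on the amide-type nitrogen. Compound 3 `O=C(Nc1ccc(Cl)cc1)Nc1nnc(Sc2ncnc3scc(-c4ccncc4)c23)s1` differs from compound 1 by 4-chlorophenyl in place of 3-(trifluoromethyl)phenyl on an amide-type nitrogen, an exchange at the same place, so that step bears on it, though the entering group is not the same one. A modest rise in this assay is therefore expected, a 1.6-fold higher number from compound 1 to compound 3 (0.21 log units; within the scatter). Compound 3 is estimated at 25000 nM, within a range from 10000 nM to 60000 nM.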

Compound 3, half-maximal inhibitory concentration: 28900 nM
Estimate against measurement, compound 3: 1.2-fold (0.06 log units) below; the measured number falls inside the stated range.
By their numbers in this assay, from the lowest: compounds 1, 3 and 2 (each within the scatter of the next, the first and the last beyond it).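

In this assay, replacing the 3-(trifluoromethyl)phenyl group on the amide-type nitrogen with 4-chlorophenyl gives (a 1.9-fold higher number from compound 1 to compound 3 (0.28 log units; within the scatter)), while chloro in place of methyl on an aromatic carbon gives (a 1.8-fold lower number from compound 2 to compound 3 (0.26 log units; within the scatter)). Compound 3 therefore cannot be separated from compound 1 or compound 2, even though those two are separated from each other, so the aryl exchanges shown form a graded series rather than two distinct levels. Nothing measured here accounts for these differences. The compounds shown leave open how an amine or a carboxylic acid on this aryl group would compare.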